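Fluoro to bromo on compound 3

The source may hold more compounds than are shown below. What is called first, only, known or untested is meant among the compounds shown, and "the series" means these compounds.

In a functional assay on MCF7 cells (Homo sapiens) for antiproliferative activity, read by MTT assay, with a stated time of 24 h (a higher number here means a weaker inhibitor, a lower number a stronger inhibitor), compound 3 `O=S(=O)(c1ccc(F)cc1)n1c(-c2cn(-c3ccccc3)nc2-c2ccc(C(F)(F)F)cc2)nc2ccccc21` gives 3120 nM, within the scatter of compound 1 `Cc1ccc(-c2nn(-c3ccccc3)cc2-c2nc3ccccc3n2S(=O)(=O)c2ccc(Br)cc2)cc1` at 3160 nM, while compound 2 `COc1ccc(S(=O)(=O)n2c(-c3cn(-c4ccccc4)nc3-c3ccc(C(F)(F)F)cc3)nc3ccccc32)cc1` gives a clearly lower 420 nM. Compound 4 `O=S(=O)(c1ccc(Br)cc1)n1c(-c2cn(-c3ccccc3)nc2-c2ccc(C(F)(F)F)cc2)nc2ccccc21` differs from compound 3 in one place: bromo in place of fluoro on an aromatic carbon. Among the measured compounds shown here, the only measured step at this place is a 7.4-fold higher number from compound 2 to compound 3 (0.87 log units; beyond the scatter), fluoro in place of methoxy, so changes here can register, though that step involves a different group. Compound 1, which differs elsewhere but also holds the (4-bromophenyl)sulfonyl group, gives 3160 nM, so no step beyond the scatter is expected in this assay. The estimated change is small, a 1.1-fold lower number from compound 3 to compound 4 (0.05 log units; within the scatter). For compound 4 the expected value is 2800 nM, with an estimated range of 1000 nM to 7500 nM.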

Compound 4, half-maximal inhibitory concentration: 2470 nM
Estimate against measurement, compound 4: 1.1-fold (0.05 log units) above; the measured number falls inside the stated range.
By their numbers in this assay, from the lowest: compound 2; then compounds 4, 3 and 1 (each within the scatter of the next).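

Bromo in place of fluoro gives a 1.3-fold lower number from compound 3 to compound 4 (0.10 log units; within the scatter) so at this place on the ring the two halogens cannot be told apart, whereas bromo in place of methoxy gives a 5.9-fold higher number from compound 2 to compound 4 (0.77 log units; beyond the scatter) and so methoxy stands apart from both halogens. With the (4-bromophenyl)sulfonyl group held constant, trifluoromethyl in place of methyl at the other end of the molecule gives a 1.3-fold lower number from compound 1 to compound 4 (0.11 log units; within the scatter) and so that swap also stays within the scatter. Nothing measured here explains why methoxy stands apart. The compounds shown leave open where an amine or a carboxylic acid at this place would fall relative to methoxy and the halogens.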